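From diethylamino to methyl: working from cytotoxicity limits

The compounds below may be only part of what the source reports. "The series", "measured", "known", "first", "only" and "open" are said of these compounds alone.

In an ADME assay on BJ cells (Homo sapiens) for cytotoxicity, with a stated time of 72 h (a higher number here means that more compound is needed for the effect, a lower number that less compound is needed), compound 1 `CCOC(=O)CNc1nc(-n2nc(-c3ccccn3)nc2N)c2cc(OC)c(OC)cc2n1` gives > 27000 nM, which is a limit of the assay. On these data alone, compound 2 `CCN(CC)c1nc(-n2nc(-c3ccccn3)nc2N)c2cc(OC)c(OC)cc2n1` gives > 9000 nM, also a limit and not a number, so its exact position is unknown. Compound 3 `COc1cc2nc(C)nc(-n3nc(-c4ccccn4)nc3N)c2cc1OC` carries methyl in place of diethylamino on an aromatic carbon, between two ring nitrogen atoms (methyl in place of diethylamino on an aromatic carbon). For the measured compounds named here, the only measured step, a step that the two limits leave unreadable from compound 1 to compound 2, gives no size to carry over, so no clear direction is expected in this assay. The expected step is a step that the limit leaves unreadable from compound 2 to compound 3. Compound 3 is estimated at 20000 nM, with an expected range of 6000 nM to 60000 nM.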

Compound 3, half-maximal effective concentration: > 13000 nM
Compound 3: only a limit was reported; the forecaster's own chance of this, stated with the estimate: 75%; the middle value does not contradict the limit.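

Compound 3, like compound 1 and compound 2, is reported only as a limit and not a number, so no step among these three compounds can be read. Where each true value lies in this assay, and whether these group changes shift it at all, stays open.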